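A Trichloroethyl Carbamate Tested Against Its Acyloxyethyl Relative

The source may hold more compounds than are shown below. What is called first, only, known or untested is meant among the compounds shown, and "the series" means these compounds.

Three compounds share one core and differ only in the group on an oxygen next to a carbonyl group. Compound 1 `CCCCCOC(=O)N1CCN(C(=O)c2nc(Nc3cc(C4CC4)[nH]n3)c3cc(Cl)ccc3n2)C[C@H]1C` carries pentyl there, compound 2 `CC(OC(=O)C(C)C)OC(=O)N1CCN(C(=O)c2nc(Nc3cc(C4CC4)[nH]n3)c3cc(Cl)ccc3n2)C[C@H]1C` carries 1-((isopropylcarbonyl)oxy)ethyl, and compound 3 `CC(C)OC(=O)N1CCN(C(=O)c2nc(Nc3cc(C4CC4)[nH]n3)c3cc(Cl)ccc3n2)C[C@H]1C` carries isopropyl. In an assay for inhibition of serine/threonine-protein kinase PAK 4 (Homo sapiens), read by FRET and Z'-LYTE, with a stated time of 60 min, tested at 50 uM, in the presence of a further agent that is not named here (on this read-out higher numbers stand for a stronger effect at the one concentration tested and lower numbers for a weaker effect), compound 1 gives 32.7%, compound 2 gives 71.7% and compound 3 gives 91.2%. Compound 2 thus stands second of the three, with compound 3 higher and compound 1 lower, both differences beyond the scatter.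

Compound 4 `C[C@@H]1CN(C(=O)c2nc(Nc3cc(C4CC4)[nH]n3)c3cc(Cl)ccc3n2)CCN1C(=O)OCC(Cl)(Cl)Cl` is made from compound 2 by 2,2,2-trichloroethyl in place of 1-((isopropylcarbonyl)oxy)ethyl on an oxygen next to a carbonyl group. Going by the values given here, three measured steps touch this same oxygen: a number 39 percentage points higher from compound 1 to compound 2 (beyond the scatter), a number 58.5 percentage points higher from compound 1 to compound 3 (beyond the scatter) and a number 19.5 percentage points higher from compound 2 to compound 3 (beyond the scatter). They show that swapping the group here moves the read-out strongly, and that the compact isopropyl sits highest while the long pentyl sits lowest. 2,2,2-trichloroethyl has not been tested, so its direction is uncertain; a step of modest size in either sense, or none beyond the scatter, seems reasonable to expect.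

The estimated step is a number 9.7 percentage points lower from compound 2 to compound 4 (within the scatter). For compound 4 the expected value in this assay is 62%, within a range from 28% to 92%.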

Compound 4, a percentage reported as inhibition, at one concentration (the size of the read-out at that concentration, not a potency): 82.8%
Compound 4: the middle estimate sits 20.8 percentage points below what was measured, within the range that was stated.
By their numbers in this assay, from the lowest: compound 1; then compound 2; then compounds 4 and 3 (each within the scatter of the next).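

In this assay, putting 2,2,2-trichloroethyl on an oxygen next to a carbonyl group gives a number 11.1 percentage points higher from compound 2 to compound 4 (beyond the scatter), so this group, with its three chlorine atoms and no hydrogen-bond acceptors, reads out above the larger 1-((isopropylcarbonyl)oxy)ethyl. Set against isopropyl, the same group gives a number 8.4 percentage points lower from compound 3 to compound 4 (within the scatter), which does not separate the two, while set against pentyl it gives a number 50.1 percentage points higher from compound 1 to compound 4 (beyond the scatter), so isopropyl is no longer the only group here that clearly outdoes both pentyl and 1-((isopropylcarbonyl)oxy)ethyl. Nothing available explains why these groups rank as they do.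

On these data alone, it remains open whether an ethyl or a 2,2,2-trifluoroethyl group on this oxygen would stand with compound 3 and compound 4 or nearer to compound 1, and so whether the chlorine atoms matter or a short chain alone is enough. Each number also comes from a single concentration, so it is still unsettled how compound 3 and compound 4 compare in potency.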